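This account rests on a few compounds, and the source may have more. Where it says the series, first, only, none or still open, it means among the compounds named here.

Compound 3 `COc1ccc(CCOC2CC(=O)Nc3c2c(C)nn3-c2ncnc3nc[nH]c23)cc1` stands level with compound 1 `Cc1nn(-c2ncnc3nc[nH]c23)c2c1C(OC1CCCC1)CC(=O)N2`, the two together giving the lowest numbers of the three. In a functional assay on HEK293 cells for agonist activity at G-protein coupled receptor 39 (Homo sapiens), read by scintillation proximity assay and inositol phosphate accumulation, with a stated time of 75 min, in the presence of a further agent that is not named here (a lower number here means that less compound is needed, a higher number that more compound is needed for the effect), compound 3 gives 2 nM, and compound 1 gives 2 nM; compound 2 `Cc1nn(-c2ncnc3nc[nH]c23)c2c1C(OCc1ccc(C(C)C)cc1)CC(=O)N2` gives 5 nM, so that a 2.5-fold lower number from compound 2 to compound 3 (0.40 log units; beyond the scatter). The change to compound 4 `Cc1nn(-c2ncnc3nc[nH]c23)c2c1C(OCc1ccccc1Cl)CC(=O)N2` is 2-chlorophenyl in place of 4-methoxybenzyl on a saturated chain carbon bound to an oxygen on a saturated carbon, which cut one bond further out reads 2-(4-methoxyphenyl)ethyl to 2-chlorobenzyl. The steps already measured at this oxygen-bound position are a 2.5-fold higher number from compound 1 to compound 2 (0.40 log units; beyond the scatter) and no change at the digits printed from compound 1 to compound 3 (within the scatter): varied groups here give nearby numbers, the largest move being modest. Compound 4 is therefore expected to show a 2.0-fold higher number from compound 3 to compound 4 (0.30 log units; within the scatter). The estimate for compound 4 is 4 nM, with a range from 1.5 nM to 12 nM.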

Compound 4, half-maximal effective concentration: 2 nM
Compound 4: middle estimate off by 2.0-fold (0.30 log units), on the high side, within the range that was stated.
By their numbers in this assay, from the lowest: compounds 1, 3 and 4 (each within the scatter of the next); then compound 2.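

Replacing 4-methoxybenzyl with 2-chlorophenyl gives no change at the digits printed from compound 3 to compound 4 (within the scatter) and the change from cyclopentyl to 2-chlorobenzyl gives no change at the digits printed from compound 1 to compound 4 (within the scatter) so this position also accepts a chlorine-bearing benzyl group on the oxygen, with a chlorine in place of the methoxy oxygen. Compound 2 remains apart from the other three, with a 2.5-fold lower number from compound 2 to compound 4 (0.40 log units; beyond the scatter) as the new step to it. Nothing available here gives a reason for these numbers.

The compounds shown leave open whether an unsubstituted benzyl, an amine or a carboxylic acid on this oxygen would stay within this narrow set of numbers.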